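The source may report more compounds than this note shows. Statements on the series, on what has been measured and on what is new or still open speak of the compounds shown alone.

Compound 1 `COc1ccc(/C=C\C(=O)O)c(OCc2cn(-c3ccc(NC(C)=O)cc3)nn2)c1CC=C(C)C` in a functional assay on A-431 cells (Homo sapiens) for cytotoxicity, read by MTT assay, with a stated time of 24 h (a higher number here means a weaker inhibitor, a lower number a stronger inhibitor), gives 23400 nM. Compound 2 `COc1ccc(/C=C\C(=O)O)c(OCc2cn(-c3ccccc3F)nn2)c1CC=C(C)C` in this assay gives 12400 nM. Compound 3 `COc1ccc(/C=C\C(=O)O)c(OCc2cn(-c3ccc(C#N)cc3)nn2)c1CC=C(C)C` in this assay gives 23000 nM.

Compound 3 stands second highest of the three numbers: its nearest neighbour is compound 1, its furthest compound 2, and both gaps lie within the scatter. Compound 4 `COc1ccc(/C=C\C(=O)O)c(OCc2cn(-c3nc4ccccc4s3)nn2)c1CC=C(C)C` arises from compound 3 by the change (1,3-benzothiazol-2-yl in place of 4-cyanophenyl on an aromatic nitrogen). Going by the values given here, the steps that bear on it all vary the group on the aromatic nitrogen: a 1.9-fold lower number from compound 1 to compound 2 (0.28 log units; within the scatter), a 1.9-fold higher number from compound 2 to compound 3 (0.27 log units; within the scatter) and a 1.0-fold lower number from compound 1 to compound 3 (0.01 log units; within the scatter), each within the scatter. Compound 4 is therefore expected to show no step beyond the scatter, with a step of a 1.2-fold lower number from compound 3 to compound 4 (0.06 log units; within the scatter). Compound 4 is estimated at 20000 nM, within a range of 8000 nM to 50000 nM.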

Compound 4, half-maximal inhibitory concentration: 20800 nM
The estimate for compound 4 lay 1.0-fold (0.02 log units) below the measured number; low and high end bracket the measured number.
By their numbers in this assay, from the lowest: compounds 2, 4, 3 and 1 (each within the scatter of the next).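

Until compound 4, only substituted phenyl groups stood on this aromatic nitrogen. 1,3-Benzothiazol-2-yl, with its five-membered aromatic ring with 2 hetero atoms, stays within the scatter of all three in this assay: a 1.1-fold lower number from compound 3 to compound 4 (0.04 log units; within the scatter), a 1.7-fold higher number from compound 2 to compound 4 (0.22 log units; within the scatter) and a 1.1-fold lower number from compound 1 to compound 4 (0.05 log units; within the scatter), so none of the four groups separates from the others. Nothing available here offers an explanation for this result. As far as these compounds go, whether a longer alkyl chain or an amine on this nitrogen would give a step beyond the scatter remains open.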